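This account rests on a few compounds, and the source may have more. Where it says the series, first, only, none or still open, it means among the compounds named here.

Working notes on the series: in an ADME assay on the whole organism (Mus musculus, strain CD-1) for pharmacokinetics, at a dose of 10 mg/kg by the oral route (on this read-out lower numbers stand for lower oral bioavailability and higher numbers for higher oral bioavailability), compound 1 `CCOc1cc([C@](O)(CCN(C)C)[C@@H](c2cc3cc(Br)ccc3nc2OC)c2ccnc(OC)c2OC)cc(OC)n1` gives 70% and compound 2 `COc1cc([C@](O)(CCN(C)C)[C@@H](c2cc3cc(Br)ccc3nc2OC)c2ccnc(OC)c2OC)cc(OC(C)C)n1` gives 22%, the lower of the two numbers. Compound 3 `CCOc1cc([C@](O)(CCN(C)C)[C@@H](c2cc3cc(Br)ccc3nc2OC)c2ccnc(OC)c2OC)cc(OC(C)C)n1` is the next case, reached from compound 2 by methyl in place of hydrogen on a saturated chain carbon bound to an oxygen on an aromatic ring, that is, methoxy to ethoxy. Among the compounds with values here, the only measured step that bears on it is a number 48 percentage points lower from compound 1 to compound 2 (beyond the scatter), which is large and beyond the scatter. That step also places methyl on hydrogen's site, but on a saturated chain carbon that is also bound to a saturated chain carbon, so it is a related change at a different place and a weak guide. A single step cannot set a trend. A small downward move is expected in this assay, probably within the scatter and much smaller than the measured step, since compound 2 at 22% already sits low. The expected step is a number 4 percentage points lower from compound 2 to compound 3 (within the scatter). Compound 3 is estimated at 18%, with an expected range of 5% to 42%.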

Compound 3, oral bioavailability: 58%
Estimate against measurement, compound 3: 40 percentage points below; measured number above the stated range.
By their numbers in this assay, from the lowest: compound 2; then compound 3; then compound 1.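

In this assay, methoxy to ethoxy gives a number 36 percentage points higher from compound 2 to compound 3 (beyond the scatter) and so shows that methyl in place of hydrogen on a saturated chain carbon bound to an oxygen on an aromatic ring can raise the number, whereas the related change at the other place gave a number 48 percentage points lower from compound 1 to compound 2 (beyond the scatter) in the earlier step. With ethoxy present in both compounds, isopropyl in place of methyl on an oxygen on an aromatic ring gives a number 12 percentage points lower from compound 1 to compound 3 (beyond the scatter) and remains a lowering change, though a modest one. Nothing on hand explains why the same added methyl moves the number in opposite directions at these two places.

Still open, on these data alone, is whether a longer chain such as propyl on this oxygen would hold or lose the rise. Also open, as far as these compounds go, is how an amine at this place would read in this assay on the shared core.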